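The source may report more compounds than this note shows. Statements on the series, on what has been measured and on what is new or still open speak of the compounds shown alone.

In a toxicity assay on WI-38 cells (Homo sapiens) for inhibition, read by MTT assay, with a stated time of 72 h (a lower number here means a stronger inhibitor, a higher number a weaker inhibitor), compound 1 `O=C(NCc1ccc(NC(=O)c2cc(Cl)ccc2N2CCCC2)cc1)OCc1cccnc1` gives > 100000 nM, which is a limit of the assay and not a number. Compound 2 `O=C(NCc1ccc(NC(=O)c2cc(C(F)(F)F)ccc2N2CCCC2)cc1)OCc1cccnc1` gives > 100000 nM, which is likewise only a limit. The two compounds therefore share a single reading: the limit of > 100000 nM in this assay, at which 2 of the 2 values shown sit. Compound 3 `O=C(NCc1ccc(NC(=O)c2cc(Br)ccc2N2CCCC2)cc1)OCc1cccnc1` has the same core as compound 2, with bromo in place of trifluoromethyl on an aromatic carbon. Among the compounds with values here, the only measured step that bears on this change is a step that the two limits leave unreadable from compound 1 to compound 2, also an exchange of one group on an aromatic carbon, and its size cannot be read. With no measured size to build on, no step beyond the scatter is expected in this assay. The expected change is a number no higher from compound 2 to compound 3 (the limit leaves the size open). Compound 3 is expected at 100000 nM, with an estimated range from 50000 nM to 200000 nM.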

Compound 3, half-maximal inhibitory concentration: > 100000 nM
Compound 3: only a limit was reported; the forecaster's own chance of this, stated with the estimate: 90%; the middle value sits exactly at the limit.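

Within the data shown here, compound 3 reports only a limit of the assay, as do compound 1 and compound 2, so no step among the three can be read: the limit of > 100000 nM in this assay, at which 3 of the 3 values shown sit. The compounds shown leave open whether chloro, trifluoromethyl and bromo differ at all in this assay.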